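The compounds below may be only part of what the source reports. "The series", "measured", "known", "first", "only" and "open" are said of these compounds alone.

Measured so far:

Compound 1, `CCOC(=O)c1c(-c2ccc(OC)c(OC)c2)csc1NC`, gives 32% in an assay on isolated protein for inhibition of protein kinase C zeta type (Homo sapiens), with stated times of 1 h and 2.5 min, tested at 30 uM; a lower number here means less inhibition, a higher number more inhibition at the concentration tested (going by the name of the read-out).
Compound 2, `COc1ccc(-c2csc(N)c2C(=O)OCc2ccccc2)cc1OC`, gives 100% in this assay.

For the measured compounds named here, on these two numbers compound 2 stands highest; the only other number, that of compound 1, is far lower, a gap well beyond the usual scatter of repeated measurements. The two compounds differ in more than one place, so no single change can be credited with that gap; the values simply show that the number of compound 2 is higher than that of compound 1 at the tested concentration.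

Compound 3, `COc1ccc(-c2csc(N)c2C(=O)NCc2ccccc2)cc1OC`, differs from compound 2 in one place: benzylamino in place of benzyloxy on a carbonyl carbon. Going by the values given here, no step of this kind has been measured here, so the size of its effect in this assay is an open question. Among the compounds with values here, because compound 2 gives 100%, the higher of the two numbers measured so far, the expected step of a number 25 percentage points lower from compound 2 to compound 3 (beyond the scatter) is a moderate drop. Compound 3 is therefore estimated to give about 75%, with a range from 40% to 100%.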

Compound 3, a percentage reported as inhibition, at one concentration (the size of the read-out at that concentration, not a potency): 43%
Beside the measured number, compound 3's estimate is 32 percentage points above it; the measured number falls inside the stated range.
By their numbers in this assay, from the lowest: compound 1; then compound 3; then compound 2.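

In this assay, for the compounds shown here, putting benzylamino in place of benzyloxy on a carbonyl carbon gives a number 57 percentage points lower from compound 2 to compound 3 (beyond the scatter), the first change here that can be read on its own, and it shows that the number responds strongly to what is attached at this carbonyl carbon. The size of the group alone does not settle the result: both groups contain the same count of heavy atoms and one six-membered aromatic ring of carbon only, yet oxygen gives way to nitrogen as the linking atom, and a hydrogen-bond acceptor on the group gives way to a hydrogen-bond donor. Nothing measured here explains why this exchange lowers the number.

The compounds shown cannot separate the effect of the nitrogen itself from that of the amide hydrogen, a question that an N-methyl-N-benzylamino group, with nitrogen but no such hydrogen, would address. They also leave open how the number would respond to a longer chain between the linking atom and the ring, such as phenethyloxy or phenethylamino in place of the benzyl groups.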